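Aortic functional series: arylsulfonylurea variants

The compounds below may be only part of what the source reports. "The series", "measured", "known", "first", "only" and "open" are said of these compounds alone.

Measured compounds:
compound 1 `Cc1ccc(OCc2ccccc2)c(C(C)NC(=O)NS(=O)(=O)c2ccc(Cl)cc2)c1`: 65300 nM
compound 2 `COc1ccc(Br)cc1C(C)NC(=O)N(C)S(=O)(=O)c1ccc(C)cc1`: 19100 nM
compound 3 `CC(NC(=O)NS(=O)(=O)c1ccc(Cl)cc1)c1ccccc1OCc1ccccc1`: 157000 nM

In a functional assay on thoracic aorta (Rattus norvegicus, strain Wistar), with a stated time of 15 min (on this read-out lower numbers stand for an effect already at smaller amounts and higher numbers for an effect only at larger amounts of compound), compound 1 gives 65300 nM, the second highest of the three numbers. Its nearest neighbour is compound 3, which gives 157000 nM. For the measured compounds named here, that pair is the only single-point change measured so far: a 2.4-fold higher number from compound 1 to compound 3 (0.38 log units; beyond the scatter). Compound 2, with 19100 nM, stands furthest from compound 1 but differs from it in several places at once, so its number shows only where the series has reached, not what any one change does.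

Compound 4 `Cc1ccc(S(=O)(=O)NC(=O)NC(C)c2cc(C)ccc2OCc2ccccc2)cc1` is the next variant: methyl in place of chloro on an aromatic carbon. Going by the values given here, no measured step bears directly on this exchange. Compound 2 does carry a (4-methylphenyl)sulfonyl group and gives the lowest number of the three, but its further differences from compound 1 leave that comparison open. Among the compounds with values here, the single measured step on this core was modest, and the present change is of similar scale, one heavy atom for one heavy atom at the same place. A step from compound 1 to compound 4 within the scatter, or at most modest in either direction, is therefore expected: a 1.3-fold lower number from compound 1 to compound 4 (0.12 log units; within the scatter). Compound 4 is estimated at 50000 nM, with a range from 20000 nM to 150000 nM.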

Compound 4, half-maximal effective concentration: 91900 nM
Compound 4: middle estimate off by 1.8-fold (0.26 log units), on the low side; measured number inside the range.
By their numbers in this assay, from the lowest: compound 2; then compounds 1, 4 and 3 (each within the scatter of the next, the first and the last beyond it).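

In this assay, 4-chlorophenyl and 4-methylphenyl cannot be told apart at this place on the shared core, the step being a 1.4-fold higher number from compound 1 to compound 4 (0.15 log units; within the scatter). For the compounds shown here, this is the first measured exchange on the (4-chlorophenyl)sulfonyl side of compound 1, and it stays within the scatter, whereas the earlier step at a different place, a 2.4-fold higher number from compound 1 to compound 3 (0.38 log units; beyond the scatter), lies beyond it, so on the present pairs the number responds to that methyl but not to chloro versus methyl on an aromatic carbon para to a large group. No supporting data are available to explain this result.

Open, going by these compounds, is whether a different kind of group at this place, such as an amine, a carboxylic acid or a longer chain, would move the number beyond the scatter, and whether the chloro to methyl exchange reads the same on the core of compound 3. Also open is what accounts for the number of compound 2, 19100 nM, since its several differences from the other compounds remain entangled in that single value.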